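From a hydroxypropyl chain to a cyclopropylmethyl chain

The source may hold more compounds than are shown below. What is called first, only, known or untested is meant among the compounds shown, and "the series" means these compounds.

Two compounds share one core and differ only in the chain on a nitrogen on an aromatic ring. In a functional assay on the whole organism for inhibition, with Nicotiana tabacum as the target (a higher number here means a weaker inhibitor, a lower number a stronger inhibitor), compound 1 `C=CCNc1nc(C)nc2[nH]ccc12` gives 676000000 nM, and compound 2 `Cc1nc(NCCCO)c2cc[nH]c2n1` gives 17800000 nM. Going by the values given here, the single measured step, a 38-fold lower number from compound 1 to compound 2 (1.58 log units; beyond the scatter), is large, so compound 2 stands at the lowest number of the two, with compound 1 as its only neighbour. Compound 3 `Cc1nc(NCC2CC2)c2cc[nH]c2n1` is not yet measured and differs from compound 2 by cyclopropyl in place of 2-hydroxyethyl on a saturated chain carbon bound to a nitrogen on an aromatic ring. Among the compounds with values here, only the step from compound 1 to compound 2 bears on this change, and it shows that the group at this position can shift the number a long way. The incoming group, like the group in compound 1, carries no hydrogen-bond donor or acceptor. A step back toward compound 1 is therefore expected, an 8.4-fold higher number from compound 2 to compound 3 (0.93 log units; beyond the scatter), smaller than a 38-fold lower number from compound 1 to compound 2 (1.58 log units; beyond the scatter). Compound 3 is expected to give about 150000000 nM, within 30000000 nM to 700000000 nM.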

Compound 3, half-maximal inhibitory concentration: 77600000 nM
For compound 3 the middle estimate is 1.9-fold (0.29 log units) above the measured one, within the range that was stated.
By their numbers in this assay, from the lowest: compound 2; then compound 3; then compound 1.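

Replacing 2-hydroxyethyl with cyclopropyl in this assay gives a modest rise (a 4.4-fold higher number from compound 2 to compound 3 (0.64 log units; beyond the scatter)), so compound 2 keeps the lowest number of the three after a second group without a hydrogen-bond donor or acceptor has been tried at this position. Those two groups do not behave alike, however: the change from vinyl to cyclopropyl also moves the number beyond the scatter (an 8.7-fold lower number from compound 1 to compound 3 (0.94 log units; beyond the scatter)), so counting donors and acceptors does not settle the value here. Nothing measured here explains why either step has its size.

The three chains leave open whether the number depends on the hydroxyl at the end of the 3-hydroxypropyl chain or on the chain itself. A methoxy group or an amine at that chain end, or a longer chain carrying the hydroxyl, would address this.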